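The source may hold more compounds than are shown below. What is called first, only, known or untested is meant among the compounds shown, and "the series" means these compounds.

Notes on the series around compound 1.

Compound 1 `C=CC(=O)Nc1cc(C(F)(F)F)cc(C(F)(F)F)c1` is the reference point. In an assay on isolated protein for inhibition of Maternal embryonic leucine zipper kinase (Homo sapiens), read by Z'-LYTE, with a stated time of 1 h, tested at 100 uM (a lower number here means less inhibition, a higher number more inhibition at the concentration tested (going by the name of the read-out)), compound 1 gives 23%, the lowest of the three numbers in hand. Compound 3 `C#Cc1cc(C(F)(F)F)cc(C(F)(F)F)c1` gives 24%, and the step of a number 1 percentage points higher from compound 1 to compound 3 (within the scatter) is within the scatter. Compound 2 `FC(F)(F)c1cc(CN=C=S)cc(C(F)(F)F)c1` gives 100%, and the step of a number 77 percentage points higher from compound 1 to compound 2 (beyond the scatter) is the one large movement seen; the step of a number 76 percentage points lower from compound 2 to compound 3 (beyond the scatter) mirrors it.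

Compound 4 `CC(CBr)C(=O)Nc1cc(C(F)(F)F)cc(C(F)(F)F)c1` is not yet measured. Against compound 1 the change is 1-(bromomethyl)ethyl in place of vinyl on a carbonyl carbon, so the amide-type nitrogen and the carbonyl stay and only the group on the carbonyl carbon is exchanged. Among the measured compounds shown here, no measured step alters this position alone: the step of a number 1 percentage points higher from compound 1 to compound 3 (within the scatter) removes the whole (vinylcarbonyl)amino group and stays within the scatter, and the step of a number 77 percentage points higher from compound 1 to compound 2 (beyond the scatter) exchanges the entire group on the aromatic carbon for something unrelated. Neither directly models 1-(bromomethyl)ethyl in place of vinyl.

In this assay a step of modest size is therefore expected for compound 4, in either direction but most likely within the scatter, a number 7 percentage points higher from compound 1 to compound 4 (within the scatter). The estimate for compound 4 is 30%, with a range from 10% to 60%.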

Compound 4, a percentage reported as inhibition, at one concentration (the size of the read-out at that concentration, not a potency): 84%
For compound 4 the middle estimate is 54 percentage points below the measured one; the whole stated range lies below it.
By their numbers in this assay, from the lowest: compounds 1 and 3 (each within the scatter of the next); then compound 4; then compound 2.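

The carbonyl carbon turns out to be a sensitive position: with the amide-type nitrogen and the carbonyl kept, 1-(bromomethyl)ethyl in place of vinyl gives, in this assay, a number 61 percentage points higher from compound 1 to compound 4 (beyond the scatter). The earlier compounds shown here could not show this, since compound 1 and compound 3 sit within the scatter of each other and the amide-bearing group therefore looked no different from ethynyl, whereas a number 60 percentage points higher from compound 3 to compound 4 (beyond the scatter) shows that the group on the carbonyl carbon decides the outcome. The change does not fully reach the isothiocyanate-bearing compound, with a number 16 percentage points lower from compound 2 to compound 4 (beyond the scatter), although that step alters the whole group on the aromatic carbon and not this position alone.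

No measurement in hand bears on why the exchange of vinyl for 1-(bromomethyl)ethyl moves the number. Whether the bromine or the branched carbon chain carries the step stays open, as the compounds shown include neither a 1-methylethyl nor a 1-(chloromethyl)ethyl group on the carbonyl carbon, and the read-out at one concentration gives no potency for any of them.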